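Swapping a benzyl arm for a nitrophenylsulfonyl arm

A few compounds are considered here, and "the series" means these few. Any claim that something is new, unique, unknown or untested is made for them only; others in the source may bear on it.

Of the compounds shown here, three built on one shared core have been tested in a functional assay on K562 cells (Homo sapiens) for antiproliferative activity, read by MTT assay and trypan blue exclusion, with a stated time of 72 h; on this read-out higher numbers stand for weaker inhibition and lower numbers for stronger inhibition. Compound 1 `COC(=O)c1ccc(C2SCC(=O)N2c2ccc(N3CCN(S(=O)(=O)c4ccccc4)CC3)cn2)c(OC)c1` gives 65600 nM in this assay. Compound 2 `COC(=O)c1ccc(C2SCC(=O)N2c2ccc(N3CCN(Cc4cccc([N+](=O)[O-])c4)CC3)cn2)c(OC)c1` carries 3-nitrobenzyl where phenylsulfonyl stands in the first compound, and in this assay compound 2 gives 68700 nM; that change amounts to a 1.0-fold higher number from compound 1 to compound 2 (0.02 log units; within the scatter). Compound 3 `COC(=O)c1ccc(C2SCC(=O)N2c2ccc(N3CCN(Cc4cccc(C)c4)CC3)cn2)c(OC)c1` reaches only the limit of this assay, > 100000 nM. Compound 3 thus sits at the limit of > 100000 nM in this assay, at which 1 of the 3 values shown sits, so only a floor is known for it, and the measured steps toward it are an at least 1.5-fold higher number from compound 1 to compound 3 (0.18 log units; that floor lies within the scatter) and an at least 1.4-fold higher number from compound 2 to compound 3 (0.16 log units; that floor lies within the scatter).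

Compound 4 `COC(=O)c1ccc(C2SCC(=O)N2c2ccc(N3CCN(S(=O)(=O)c4ccc([N+](=O)[O-])cc4)CC3)cn2)c(OC)c1` differs from compound 3 in one place: (4-nitrophenyl)sulfonyl in place of 3-methylbenzyl on an amine nitrogen in a ring. Going by the values given here, two measured steps bear on this change. The step of an at least 1.5-fold higher number from compound 1 to compound 3 (0.18 log units; that floor lies within the scatter) shows that moving from phenylsulfonyl to 3-methylbenzyl on the ring nitrogen weakens inhibition at least a little, and an at least 1.4-fold higher number from compound 2 to compound 3 (0.16 log units; that floor lies within the scatter) shows that methyl in place of nitro does the same. Both point toward a lower number for compound 4. Compound 1, which already bears phenylsulfonyl at that nitrogen, gives 65600 nM, and that value anchors the expectation. The expected step is an at least 1.6-fold lower number from compound 3 to compound 4 (0.22 log units; that floor lies within the scatter), toward a somewhat lower number. Compound 4 is therefore estimated at 60000 nM, with a range from 25000 nM to 150000 nM.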

Compound 4, half-maximal inhibitory concentration: 65200 nM
Estimate against measurement, compound 4: 1.1-fold (0.04 log units) below, and the stated range covers the measured number.
By their numbers in this assay, from the lowest: compounds 4, 1 and 2 (each within the scatter of the next). At a limit, above all of these: compound 3.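

In this assay, the new arm gives a result that cannot be told apart from either earlier measured arm: adding nitro to the phenylsulfonyl of compound 1 gives a 1.0-fold lower number from compound 1 to compound 4 (0.00 log units; within the scatter), and exchanging 3-nitrobenzyl for (4-nitrophenyl)sulfonyl gives a 1.1-fold lower number from compound 2 to compound 4 (0.02 log units; within the scatter). At this ring nitrogen, then, compounds 1, 2 and 4 show no measurable preference among these three arms, whether the link is sulfonyl or benzyl and whether or not the aromatic ring carries nitro. The step from the 3-methylbenzyl arm is an at least 1.5-fold lower number from compound 3 to compound 4 (0.18 log units; that floor lies within the scatter), so it adds only a floor and does not separate compound 3 from compound 4. Compound 3 itself is held at a limit of the assay: the limit of > 100000 nM in this assay, at which 1 of the 4 values shown sits.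

From the compounds shown here alone, it remains open whether an amine or a carboxylic acid on the aromatic ring of this arm, or a longer chain in place of the benzyl link, would bring the number beyond the scatter of these values. Also open, going by these compounds, is the true value of compound 3, and with it whether 3-methylbenzyl truly differs from the other arms at this position.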